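The compounds below may be only part of what the source reports. "The series", "measured", "known", "first", "only" and "open" are said of these compounds alone.

Measured in a functional assay on A549 cells (Homo sapiens) for antiproliferative activity, read by MTT assay; on this read-out lower numbers stand for stronger inhibition and higher numbers for weaker inhibition:
- Compound 1 `COc1cccc(/C=N/Nc2ncc3c(n2)n(C2CCCC2)c(=O)c(=O)n3C)c1`: 27400 nM
- Compound 2 `Cn1c(=O)c(=O)n(C2CCCC2)c2nc(N/N=C/c3cccc(O)c3)ncc21`: > 100000 nM, a limit of the assay and not a number

Compound 2 has no exact place on the scale, and it stands at the limit of > 100000 nM in this assay, at which 1 of the 2 values shown sits. Within the data shown here, the one measured step is an at least 3.6-fold higher number from compound 1 to compound 2 (0.56 log units; beyond the scatter), and it comes with hydrogen in place of methyl on an oxygen on an aromatic ring.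

Compound 3 `Cn1c(=O)c(=O)n(C2CCCC2)c2nc(N/N=C/c3ccc(O)c(Br)c3)ncc21` differs from compound 2 on that same aromatic ring: 3-bromo-4-hydroxyphenyl in place of 3-hydroxyphenyl on a carbon with a double bond to nitrogen. In words, 3-bromo-4-hydroxyphenyl replaces 3-hydroxyphenyl on a carbon with a double bond to nitrogen. Compound 3 keeps a free hydroxy group, as compound 2 does, so the measured step is only a loose guide. It does show that a change on this ring can move the number in this assay. On that single precedent, a modest shift towards lower numbers is expected, in the direction of compound 1 at 27400 nM. Compound 3 may still stay at the limit of the assay.

The expected change is an at least 2.2-fold lower number from compound 2 to compound 3 (0.34 log units; beyond the scatter).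

For compound 3 the estimate is 45000 nM, with an expected range of 15000 nM to 100000 nM.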

Compound 3, half-maximal inhibitory concentration: 12800 nM
Compound 3: the middle estimate sits 3.5-fold (0.55 log units) above what was measured; the measured number lies below the stated range.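

In this assay a free hydroxy group on this ring no longer goes with a value at the limit: 3-bromo-4-hydroxyphenyl in place of 3-hydroxyphenyl gives an at least 7.8-fold lower number from compound 2 to compound 3 (0.89 log units; beyond the scatter) and so this ring can shift the number by more than the loss of a methyl group alone suggested. As far as these compounds go, the true size of that step stays unknown, as the value of compound 2 is a limit of the assay and not a number: the limit of > 100000 nM in this assay, at which 1 of the 3 values shown sits. The methoxy group is also not needed for a measurable value, since 3-bromo-4-hydroxyphenyl in place of 3-methoxyphenyl gives a 2.1-fold lower number from compound 1 to compound 3 (0.33 log units; beyond the scatter) and this makes compound 3 the compound with the lowest number of the three.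

The change from compound 2 to compound 3 both adds a bromine and alters where the hydroxy group stands, so the compounds shown do not tell which of the two carries the step; a plain 4-hydroxyphenyl group or a 3-bromophenyl group would separate them. From the compounds shown here alone, how a chlorine or an amine on this ring would read also remains open, and all three numbers still belong to a single cyclopentyl-bearing core.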